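The source may report more compounds than this note shows. Statements on the series, on what has been measured and on what is new or still open speak of the compounds shown alone.

In a physicochemical assay for lipophilicity (on this read-out higher numbers stand for higher lipophilicity and lower numbers for lower lipophilicity), compound 1 (`CCOC[C@H](Oc1ncnc2c1cnn2-c1ncccc1Cl)C(=O)Nc1ccccn1`) gives 2.1 and stands lowest of the three measured compounds. Compound 3 (`COC[C@H](Oc1ncnc2c1cnn2-c1ccccc1Cl)C(=O)Nc1ccc(C)cn1`) gives 3.4 and compound 2 (`Cc1ccc(NC(=O)[C@H](COC(C)C)Oc2ncnc3c2cnn3-c2ccccc2Cl)nc1`) gives 3.9 on the same scale, both beyond the scatter from compound 1. Next in line is compound 4 (`CCOC[C@H](Oc1ncnc2c1cnn2-c1ncccc1Cl)C(=O)Nc1cnc(C)cn1`), with 5-methylpyrazin-2-yl in place of pyridin-2-yl on an amide-type nitrogen. The change from compound 1 is 5-methylpyrazin-2-yl in place of pyridin-2-yl on an amide-type nitrogen and the rest of the structure stays the same.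

Going by the values given here, no measured step covers this exchange. Among the compounds with values here, the only step between compounds differing in one place is a number 0.50 log units lower from compound 2 to compound 3 (beyond the scatter) for methyl in place of isopropyl on an oxygen on a saturated carbon. That modest step lies elsewhere in the structure and serves only as a guide to size. The larger gaps between compound 1 and compounds 2 and 3 span several differences and cannot be assigned to any single one. Going by these compounds, on this thin evidence only a small step is expected, a number 0.10 log units lower from compound 1 to compound 4 (within the scatter) as the estimate, and it is not expected to lie beyond the scatter, with either direction still open. Compound 4 is estimated at 2 with an expected range from 1.5 to 2.5 in this measurement.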

Compound 4, distribution coefficient: 1.8
Compound 4: middle estimate off by 0.20 log units, on the high side; the range from low to high includes it.
By their numbers in this assay, from the lowest: compounds 4 and 1 (each within the scatter of the next); then compound 3; then compound 2.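

In this assay, the exchange of pyridin-2-yl for 5-methylpyrazin-2-yl on the amide-type nitrogen gives a number 0.30 log units lower from compound 1 to compound 4 (within the scatter), the first step read at this position of the series. Going by these compounds alone, the earlier compounds offered only a step at the oxygen on a saturated carbon, so this is the first direct reading of a change in the aromatic ring on the amide. The entering group brings a methyl and a second ring nitrogen in a single exchange, and this pair of compounds shows the two together without a step beyond the scatter, while giving no separate reading for either; no supporting measurement bears on the result.

Still open, going by these compounds, is what each part of the exchange does alone, which would take unsubstituted pyrazin-2-yl on the same amide-type nitrogen, with the rest of compound 1 kept. Also open, on these data alone, is how far this position tolerates larger or differently functionalised groups, such as a longer chain in 5-ethylpyrazin-2-yl, an amine in 5-aminopyrazin-2-yl, or a carboxylic acid on the same ring.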